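The compounds below may be only part of what the source reports. "The series", "measured", "known", "first", "only" and "open" are said of these compounds alone.

Compound 1 `Cc1ccc([C@H](C)NC(=O)Cn2nnc3ccccc3c2=O)c(F)c1` sits lowest among the three measured compounds in an ADME assay on microsomes from liver (Homo sapiens) for metabolic stability (on this read-out higher numbers stand for fast clearance and lower numbers for slow clearance), where compound 1 gives 28 mL/min/kg. Compound 2 `Cc1ccc([C@H](C)NC(=O)Cn2nnc3ccc(C)cc3c2=O)cc1` gives 179 mL/min/kg in this assay, and compound 3 `Cc1ccc([C@H](C)NC(=O)Cn2nnc3ccc(C(F)(F)F)cc3c2=O)cc1` gives 435 mL/min/kg. The step of a 2.4-fold higher number from compound 2 to compound 3 (0.39 log units; beyond the scatter) corresponds to trifluoromethyl in place of methyl on an aromatic carbon, a change made on a ring that is part of a fused system of two rings, meta to a fused ring and para to a fused ring. The difference between the cores of compound 1 and compound 2 is not broken down here.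

Compound 4 `C[C@H](NC(=O)Cn1nnc2ccccc2c1=O)c1ccc(C(F)(F)F)cc1F` is unmeasured; it differs from compound 1 by trifluoromethyl in place of methyl on an aromatic carbon, the same kind of change as before, but here on a ring of carbon only, meta to a fluoro group and para to a large group. In this assay compound 4 is expected to show a step of a 1.8-fold higher number from compound 1 to compound 4 (0.25 log units; within the scatter), resting on the step of a 2.4-fold higher number from compound 2 to compound 3 (0.39 log units; beyond the scatter) made by the same kind of change. The estimate for compound 4 is 50 mL/min/kg, expected to fall between 20 mL/min/kg and 120 mL/min/kg.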

Compound 4, clearance: 17 mL/min/kg
The estimate for compound 4 lay 2.9-fold (0.47 log units) above the measured number, and the stated range ends above it.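

In this assay, among these compounds, trifluoromethyl in place of methyl on the ring of carbon only gave a 1.6-fold lower number from compound 1 to compound 4 (0.22 log units; within the scatter), so on this core the change leaves no step that can be told apart from the scatter. The change did not carry over as a fixed step from one core to the other: the same change on two cores in this assay, a 2.4-fold higher number (0.39 log units; beyond the scatter) from compound 2 to compound 3 and a 1.6-fold lower number (0.22 log units; within the scatter) from compound 1 to compound 4, 4.0-fold (0.60 log units) apart, beyond the scatter of two such steps

This rests on one pair per core, and the change sits on a different ring in each pair, so it does not show which difference between the compounds sets the gap, or how the change would read on a further core. The compounds shown leave open what a nitrile or a methoxy group would give in that same place in this assay. They also leave open whether the change reads the same on the ring of carbon only without the fluoro group.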